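This account rests on a few compounds, and the source may have more. Where it says the series, first, only, none or still open, it means among the compounds named here.

Measured compounds:
compound 1, `COc1ccc(Cl)cc1C(=O)NCCC1CCN(S(=O)(=O)NC(=O)NC[C@@H]2C[C@@H]3C=C[C@@H]2C3)CC1`, gives 27%
compound 2, `Cn1cccc(C(=O)NCCC2CCN(S(=O)(=O)NC(=O)NC[C@@H]3C[C@@H]4C=C[C@@H]3C4)CC2)c1=O`, gives 19%

Both numbers come from a functional assay on the whole organism (blood) with Rattus norvegicus as the target, with stated times of 24 h and 1 h, at a dose of 1 mg/kg by the intraperitoneal route; on this read-out higher numbers stand for a stronger effect at the one dose given and lower numbers for a weaker effect. Compound 2 has the lower of the two numbers, but its gap to compound 1 lies within the scatter, so the two cannot be told apart on these data. Compound 3, `O=C(NC[C@@H]1C[C@@H]2C=C[C@@H]1C2)NS(=O)(=O)N1CCC(CCNC(=O)c2nc3ccccc3s2)CC1`, has not yet been measured. It differs from compound 2 in one place, on a carbonyl carbon: a group of 9 heavy atoms (7 carbon, 1 nitrogen, 1 sulfur; one five-membered aromatic ring with 2 hetero atoms, one six-membered aromatic ring of carbon only) in place of a group of 8 heavy atoms (6 carbon, 1 nitrogen, 1 oxygen; one six-membered aromatic ring with 1 hetero atom), on a carbonyl carbon. Among the compounds with values here, the only measured step that bears on this is the one at the same carbonyl carbon, where a number 8 percentage points lower from compound 1 to compound 2 (within the scatter). That exchange of one aromatic group for another at this position left the read-out essentially unchanged, so for the new exchange a step of little size, or none beyond the scatter, is expected in this assay. Compound 3 is therefore estimated at 24%, with a range from 5% to 45%. This corresponds to an expected step of a number 5 percentage points higher from compound 2 to compound 3 (within the scatter).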

Compound 3, a percentage reported as activity, at one dose (the size of the read-out at that dose, not a potency): 14%
Estimate against measurement, compound 3: 10 percentage points above; the measured number falls inside the stated range.
By their numbers in this assay, from the lowest: compounds 3, 2 and 1 (each within the scatter of the next, the first and the last beyond it).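

In this assay, this position now shows a step that clears the scatter, with 1,3-benzothiazol-2-yl in place of 5-chloro-2-methoxyphenyl on the carbonyl carbon: a number 13 percentage points lower from compound 1 to compound 3 (beyond the scatter). The other new exchange stays small, a number 5 percentage points lower from compound 2 to compound 3 (within the scatter), so compound 2 cannot be told apart from either neighbour, and the group on this carbonyl carbon is seen to move the read-out only modestly, with only the two ends of the series separated. Nothing measured here offers an explanation for this modest separation.

All three groups shown at this position are aromatic, so the effect of a cyclohexyl ring or a simple ethyl chain on this carbonyl carbon remains open. Each number also comes from a single dose, which leaves open whether the same separation would appear at other doses.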